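Swapping the Outer Ring Substituent for a Pyridine

The compounds below may be only part of what the source reports. "The series", "measured", "known", "first", "only" and "open" are said of these compounds alone.

Of the compounds shown here, three sharing one core have been measured in a functional assay on FM3A cells (Mus musculus) for antiproliferative activity; a higher number here means a weaker inhibitor, a lower number a stronger inhibitor. Compound 1 `COc1cc(C(=O)c2sc(-c3ccc(F)cc3)cc2N)cc(OC)c1OC` gives 16 nM. Compound 2 `COc1cc(C(=O)c2sc(-c3cc(OC)c(OC)c(OC)c3)cc2N)cc(OC)c1OC` gives 3500 nM. Compound 3 `CCOc1ccc(-c2cc(N)c(C(=O)c3cc(OC)c(OC)c(OC)c3)s2)cc1` gives 510 nM, the second highest of the three numbers, sitting far from compound 1 and nearer to compound 2. For the measured compounds named here, the one measured step that alters the same outer ring, a 32-fold higher number from compound 1 to compound 3 (1.50 log units; beyond the scatter), was large, and the trimethoxyphenyl analogue compound 2 lies higher still, so the outer ring matters.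

Compound 4 `COc1cc(C(=O)c2sc(-c3ccncc3)cc2N)cc(OC)c1OC` carries the change (pyridin-4-yl in place of 4-ethoxyphenyl on an aromatic carbon). Going by the values given here, no measured step exchanges an ethoxyphenyl for a pyridinyl, so the direction must be inferred. Among the measured compounds the smaller substituted ring went with the lowest number, and pyridin-4-yl is smaller than 4-ethoxyphenyl, so a drop is expected, though how far is uncertain. Compound 4 is expected to give 80 nM, within a range of 15 nM to 500 nM. The expected step is a 6.4-fold lower number from compound 3 to compound 4 (0.80 log units; beyond the scatter).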

Compound 4, half-maximal inhibitory concentration: 150 nM
Compound 4: middle estimate off by 1.9-fold (0.27 log units), on the low side; the measured number falls inside the stated range.
By their numbers in this assay, from the lowest: compound 1; then compound 4; then compound 3; then compound 2.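

Putting pyridin-4-yl in place of 4-ethoxyphenyl next to the ring sulfur gives a 3.4-fold lower number from compound 3 to compound 4 (0.53 log units; beyond the scatter) in this assay and shows that an outer ring with a hetero atom can sit at this position. The same pyridin-4-yl set against 4-fluorophenyl gives a 9.4-fold higher number from compound 1 to compound 4 (0.97 log units; beyond the scatter) and leaves compound 1 with the lowest number of the four. Ring size alone therefore does not order these compounds, since the smaller pyridin-4-yl lies above 4-fluorophenyl.

Still open, from the compounds shown here alone, is where a plain phenyl group would fall, and whether a methyl group or an amine on the pyridine ring would move the number up or down. Nothing shown here explains why these outer rings differ.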